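The source may hold more compounds than are shown below. What is called first, only, known or untested is meant among the compounds shown, and "the series" means these compounds.

Measured so far:
compound 1, `COc1cc(/C(Cl)=C/C=C(\C#N)C(=O)c2c[nH]c3ccccc23)cc(OC)c1OC` — 73.3%
compound 2, `COc1cc(/C(Cl)=C/C=C(\C#N)C(=O)c2c[nH]c3ccc(Br)cc23)cc(OC)c1OC` — 36.7%
compound 3, `COc1ccc(/C(Cl)=C/C=C(\C#N)C(=O)c2c(C)[nH]c3ccccc23)cc1OC` — 75.8%

In a functional assay for inhibition, read by Griess assay, with a stated time of 150 min, tested at 1 mM (a higher number here means more inhibition at the concentration tested (going by the name of the read-out), a lower number less inhibition), compound 3 gives 75.8%, the highest of the three numbers. Compound 1 gives 73.3%, which lies within the scatter of compound 3, so no order can be read between these two. Compound 2 gives 36.7%, beyond the scatter below compound 3. Within the data shown here, the single measured step is a number 36.6 percentage points lower from compound 1 to compound 2 (beyond the scatter), a bromo in place of hydrogen on an aromatic carbon of the shared core, and it does not touch the ring changed here.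

Compound 4 is `COc1cc(/C(Cl)=C/C=C(\C#N)C(=O)c2c(C)[nH]c3ccccc23)cc(OC)c1OC`. Relative to compound 3 the change is methoxy in place of hydrogen on an aromatic carbon. Among the measured compounds shown here, no measured step bears on this change directly. Compound 1 and compound 3 differ in two places, yet their values sit within the scatter of each other, which gives no hint that a third methoxy shifts the read-out. The expectation is therefore no step beyond the scatter, a number 1.8 percentage points lower from compound 3 to compound 4 (within the scatter). For compound 4 the estimate is 74%, with a range from 60% to 88%.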

Compound 4, a percentage reported as inhibition, at one concentration (the size of the read-out at that concentration, not a potency): 74.2%
Estimate against measurement, compound 4: 0.2 percentage points below, and the stated range covers the measured number.
By their numbers in this assay, from the lowest: compound 2; then compounds 1, 4 and 3 (each within the scatter of the next).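

In this assay, methoxy in place of hydrogen on an aromatic carbon, ortho to a methoxy group, gives a number 1.6 percentage points lower from compound 3 to compound 4 (within the scatter) and so leaves the read-out unseparated at this place on the ring, while the added methyl gives a number 0.9 percentage points higher from compound 1 to compound 4 (within the scatter) on a ring bearing three methoxy groups. The step of a number 37.5 percentage points higher from compound 2 to compound 4 (beyond the scatter) exchanges 5-bromo-1H-indol-3-yl for 2-methyl-1H-indol-3-yl, and with the methyl step within the scatter, the large difference tracks the bromo rather than the methyl. No measurement offers an explanation for these steps.

Open, on these data alone, is whether this place on the ring accepts groups other than methoxy, such as a hydroxyl or an amine. Also open, as far as these compounds go, is whether a longer chain such as ethyl matches the methyl on the shared core.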